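The source may hold more compounds than are shown below. What is called first, only, known or untested is meant among the compounds shown, and "the series" means these compounds.

Compound 1 `COc1ccc(NS(=O)(=O)c2ccc(N3CCNC3=O)cc2)cc1` opens the series in a functional assay on MCF7 cells (Homo sapiens) for antiproliferative activity, read by sulforhodamine B assay, with a stated time of 48 h; on this read-out lower numbers stand for stronger inhibition and higher numbers for weaker inhibition. In this assay compound 1 gives > 1000 nM, which is a limit of the assay rather than a number. Compound 2 `CCCCOc1ccc(NS(=O)(=O)c2ccc(N3CCNC3=O)cc2)cc1` gives 870 nM in this assay. Compound 3 `CC(C)Cc1ccc(NS(=O)(=O)c2ccc(N3CCNC3=O)cc2)cc1` returns > 1000 nM in this assay, again a limit. Two of the three values thus sit at the same limit (the limit of > 1000 nM in this assay, at which 2 of the 3 values shown sit), so compound 1 cannot be placed against compound 3 at all. For the measured compounds named here, its only neighbour with a number is compound 2: the step of an at least 1.1-fold lower number from compound 1 to compound 2 (0.06 log units; that floor lies within the scatter) is a floor that stays within the scatter. The step that the two limits leave unreadable from compound 1 to compound 3, and an at least 1.1-fold higher number from compound 2 to compound 3 (0.06 log units; that floor lies within the scatter) is once more only a floor within the scatter.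

Compound 4 `Cc1cccc(NS(=O)(=O)c2ccc(N3CCNC3=O)cc2)c1C` differs from compound 1 by 2,3-dimethylphenyl in place of 4-methoxyphenyl on a sulfonamide nitrogen. Going by the values given here, none of the measured steps carries this change: the steps from compound 1 exchange methoxy for butoxy or isobutyl, whereas here 2,3-dimethylphenyl enters in place of 4-methoxyphenyl. Since every measured step is within the scatter or unreadable, the expected step of a number no higher from compound 1 to compound 4 (the limit leaves the size open) in this assay is none beyond the scatter. Compound 4 is therefore expected to give about 1000 nM in this assay, between 450 nM and 2500 nM, with a fair chance that only a limit is reported.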

Compound 4, half-maximal inhibitory concentration: 230 nM
The estimate for compound 4 lay 4.3-fold (0.64 log units) above the measured number; the whole stated range lies above it.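

In this assay, for the compounds shown here, putting 2,3-dimethylphenyl in place of 4-methoxyphenyl on the sulfonamide nitrogen gives an at least 4.3-fold lower number from compound 1 to compound 4 (0.63 log units; beyond the scatter), the first step printed as beyond the scatter. The earlier steps shown here at this place changed only the methoxy group, to butoxy or to isobutyl, and those steps either stayed within the scatter or could not be read, so they gave no sign that the group on this nitrogen could move the number at all. The new step is a floor and not a full size because compound 1 carries only a limit of the assay, and that limit is shared by a second compound: the limit of > 1000 nM in this assay, at which 2 of the 4 values shown sit.

The compounds shown leave open whether both methyl groups of compound 4 are needed, or whether a phenyl group carrying a single methyl would give a similar number in this assay. They also leave open whether chlorine or an amine in place of those methyl groups would keep the number, and they give no measured property that would explain the step.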